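This account rests on a few compounds, and the source may have more. Where it says the series, first, only, none or still open, it means among the compounds named here.

Compound 1 `COC(=O)CCCNC(=O)c1cc(C)cc2c1NC(C)(C)C=C2C` gives > 30000 nM (a limit)
Compound 2 `COC(=O)/C=C/CNC(=O)c1cccc2c1NC(C)(C)C=C2C` gives > 30000 nM (a limit)

In an ADME assay on HeLa cells (Homo sapiens) for cytotoxicity (on this read-out higher numbers stand for lower toxicity in this test and lower numbers for higher toxicity in this test), compound 2 gives > 30000 nM as a limit of the assay, not a number. It stands with the other measured compound (the limit of > 30000 nM in this assay, at which 2 of the 2 values shown sit). Compound 3 `COC(=O)CCCNC(=O)c1cccc2c1NC(C)(C)C=C2C` has 2-(methoxycarbonyl)ethyl in place of 2-(methoxycarbonyl)ethenyl on a saturated chain carbon bound to an amide-type nitrogen. Among the measured compounds shown here, no measured step gives a size for this change, and in this assay none beyond the scatter is expected. The estimated change is a number no higher from compound 2 to compound 3 (the limit leaves the size open) and no more. Compound 3 is estimated at 30000 nM with an expected range of 15000 nM to 60000 nM on this read-out.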

Compound 3, half-maximal cytotoxic concentration: > 30000 nM
Compound 3 gave a limit, no number (the forecaster's own chance of this, stated with the estimate: 85%); the middle value sits exactly at the limit.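

Compound 3 gives a limit, not a number, as do compound 1 and compound 2, so neither step to compound 3 can be read in this assay. The compounds shown leave open whether either change alters the read-out at all: the limit of > 30000 nM in this assay, at which 3 of the 3 values shown sit.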